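Restoring the benzyl amide: from compound 3 to compound 4

This account rests on a few compounds, and the source may have more. Where it says the series, first, only, none or still open, it means among the compounds named here.

Compound 3 `C=CC1=C(C(=O)Nc2ccccc2)C(c2ccc(OC)cc2)OC1` stands at the edge of what a functional assay on HeLa cells (Homo sapiens) for cytotoxicity, read by MTT assay, with a stated time of 24 h (a lower number here means a stronger inhibitor, a higher number a weaker inhibitor), can report: in this assay compound 3 gives > 100000 nM, which is a limit rather than a number. Compound 2 `C=CC1=C(C(=O)Nc2ccc(C)cc2)C(c2ccc(OC)cc2)OC1` likewise reaches only a limit, giving > 100000 nM. Going by the values given here, compound 1 `C=CC1=C(C(=O)NCc2ccc(C)cc2)C(c2ccc(OC)cc2)OC1` is the one member of the set with a measured value, 15900 nM. Two of the three values shown thus sit at the limit of > 100000 nM in this assay, at which 2 of the 3 values shown sit, and the step that the two limits leave unreadable from compound 2 to compound 3 cannot be read.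

The change to compound 4 `C=CC1=C(C(=O)NCc2ccccc2)C(c2ccc(OC)cc2)OC1` is benzyl in place of phenyl on an amide-type nitrogen. The measured steps that bear on it run the opposite way: an at least 6.2-fold higher number from compound 1 to compound 2 (0.79 log units; beyond the scatter) and an at least 6.2-fold higher number from compound 1 to compound 3 (0.79 log units; beyond the scatter), each raising the number beyond the scatter. Reversing that kind of change is expected to lower the number, and nothing in the set points the other way. Compound 4 is therefore expected to give 20000 nM, with a range from 8000 nM to 60000 nM. The step this estimate means is an at least 5.0-fold lower number from compound 3 to compound 4 (0.69 log units; beyond the scatter).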

Compound 4, half-maximal inhibitory concentration: > 100000 nM
Compound 4: no number, only a limit; the forecaster's own chance of this, stated with the estimate: 25%; at least 5.0-fold (0.69 log units) between middle value and limit.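

Hydrogen in place of methyl on an aromatic carbon of the benzyl group gives an at least 6.2-fold higher number from compound 1 to compound 4 (0.79 log units; beyond the scatter), so in this assay the benzyl amide alone does not bring a measured value; among the compounds shown, only the 4-methylbenzyl amide of compound 1 does. Compound 2 and compound 3 could not show this, since the same change between them ends in limits on both sides. The steps from compound 3 to compound 4 and from compound 2 to compound 4 cannot be read either, because each of these compounds gives a limit and not a number: the limit of > 100000 nM in this assay, at which 3 of the 4 values shown sit.

From the compounds shown here alone, whether a chlorine atom, a methoxy group or an ethyl group in the place of that methyl would also give a measured value stays open. So does how far compound 2, compound 3 and compound 4 lie beyond their limits.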